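This account rests on a few compounds, and the source may have more. Where it says the series, first, only, none or still open, it means among the compounds named here.

Compound 1 `Cc1ccc(NCc2cn(-c3ccccc3)nc2-c2ccc(C(F)(F)F)cc2)cc1` and compound 2 `Cc1ccc(NCc2cn(-c3ccccc3)nc2-c2ccccc2)cc1` share a core; compound 3 `Cc1ccc(-c2nn(-c3ccccc3)cc2CNc2ccccc2)cc1` holds the same atoms joined differently, and how the two cores differ is not broken down here. In an ADME assay on Vero 76 cells (Chlorocebus sabaeus) for cytotoxicity, read by MTT assay, with a stated time of 96 h (on this read-out lower numbers stand for higher toxicity in this test and higher numbers for lower toxicity in this test), compound 1 gives 82000 nM. In this assay compound 2 reports only a limit of the assay, > 100000 nM. That limit, (the limit of > 100000 nM in this assay, at which 1 of the 3 values shown sits), is where one of the three values sits. In this assay compound 3 gives 52000 nM, within the scatter of compound 1. The change from compound 2 to compound 1, (trifluoromethyl in place of hydrogen on an aromatic carbon), gave an at least 1.2-fold lower number from compound 2 to compound 1 (0.08 log units; that floor lies within the scatter). Compound 4 `Cc1ccc(-c2nn(-c3ccccc3)cc2CNc2ccc(C(F)(F)F)cc2)cc1`, not yet measured, carries the same change relative to compound 3: trifluoromethyl in place of hydrogen on an aromatic carbon. Because an at least 1.2-fold lower number from compound 2 to compound 1 (0.08 log units; that floor lies within the scatter) has a floor lying within the scatter, for compound 4 the expected step is small, a 1.3-fold lower number from compound 3 to compound 4 (0.11 log units; within the scatter). Compound 4 is estimated in this assay at 40000 nM, between 20000 nM and 80000 nM.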

Compound 4, half-maximal cytotoxic concentration: 45000 nM
Estimate against measurement, compound 4: 1.1-fold (0.05 log units) below; low and high end bracket the measured number.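

In this assay, trifluoromethyl in place of hydrogen on an aromatic carbon gives a 1.2-fold lower number from compound 3 to compound 4 (0.06 log units; within the scatter), so on the core of compound 3 the change shows no step beyond the scatter. Whether the change carries from one core to the other with the same size stays unsettled: the same change on two cores in this assay, an at least 1.2-fold lower number (0.08 log units; that floor lies within the scatter) from compound 2 to compound 1 and a 1.2-fold lower number (0.06 log units; within the scatter) from compound 3 to compound 4; the limit leaves it open whether they differ. Compound 2 stands at a limit of the assay, > 100000 nM, and not at a measured number.

Still open, going by these compounds, is whether a different group on that aromatic carbon, such as a nitrile, an amine or a carboxylic acid, would give a step beyond the scatter on either core. Also open is how trifluoromethyl would read on the other aromatic rings of these compounds.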